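Trimming the sulfonyl side chain: isopropyl to ethyl

The source may hold more compounds than are shown below. What is called first, only, known or untested is meant among the compounds shown, and "the series" means these compounds.

Compound 1, `CC(C)S(=O)(=O)N(Cc1ccccc1-c1ccccc1)[C@H]1CCNC1`: 2700 nM
Compound 2, `CC(C)C(=O)N(Cc1ccccc1C(C)C)[C@H]1CCNC1`: 3410 nM

In an assay on HEK293 cells for inhibition of sodium-dependent dopamine transporter (Homo sapiens) (on this read-out higher numbers stand for weaker inhibition and lower numbers for stronger inhibition), compound 1 gives 2700 nM and compound 2 gives 3410 nM; the two lie within the scatter of each other, so neither stands apart. Compound 3, `CCS(=O)(=O)N(Cc1ccccc1-c1ccccc1)[C@H]1CCNC1`, differs from compound 1 by hydrogen in place of methyl on a saturated chain carbon bound to a saturated chain carbon and a sulfonyl sulfur, that is, isopropylsulfonyl to ethylsulfonyl. Among the measured compounds shown here, no measured pair shows this change, so its size is unknown; the loss of a single methyl at this place is expected to give a step in this assay of no more than the scatter, in no clear direction. Compound 3 is therefore estimated at 3000 nM, between 1200 nM and 7500 nM. The expected step is a 1.1-fold higher number from compound 1 to compound 3 (0.05 log units; within the scatter).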

Compound 3, inhibition constant: 2760 nM
Compound 3: middle estimate off by 1.1-fold (0.04 log units), on the high side, within the range that was stated.
By their numbers in this assay, from the lowest: compounds 1, 3 and 2 (each within the scatter of the next).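

Among the compounds shown here, the step of a 1.0-fold higher number from compound 1 to compound 3 (0.01 log units; within the scatter) in this assay gives isopropylsulfonyl to ethylsulfonyl a measured size, which the earlier compounds did not. On a saturated chain carbon bound to a saturated chain carbon and a sulfonyl sulfur, this methyl can therefore be exchanged for hydrogen without a readable effect on this read-out. No evidence on the reason for this is available.

The compounds shown leave open how a methylsulfonyl group, a longer chain such as butylsulfonyl, or a carboxylic acid on that chain would read. They also do not show whether this result holds on other cores.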